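The source may report more compounds than this note shows. Statements on the series, on what has been measured and on what is new or still open speak of the compounds shown alone.

Compound 1 `COc1ccc(S(=O)(=O)N2CCc3cccc(-c4ccc(F)nc4)c32)cc1`: 145 nM
Compound 2 `COc1ccc(S(=O)(=O)N2CCc3cccc(-c4ccc(N(C)C)cc4)c32)cc1`: 237 nM
Compound 3 `COc1ccc(S(=O)(=O)N2CCc3cccc(-c4cc(OC)c(OC)c(OC)c4)c32)cc1`: 1080 nM

These three compounds share one core and differ in the aromatic group it carries, and all were tested in a functional assay on MKN-45 cells (Homo sapiens) for inhibition, with a stated time of 72 h; on this read-out higher numbers stand for weaker inhibition and lower numbers for stronger inhibition. Compound 2 gives 237 nM, which lies within the scatter of compound 1. Compound 3 gives a clearly higher number than compound 2.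

The next compound is compound 4 `COc1ccc(S(=O)(=O)N2CCc3cccc(-c4cccc(F)c4)c32)cc1`, not yet measured in this assay. It carries 3-fluorophenyl in place of the 4-(dimethylamino)phenyl of compound 2, on an aromatic carbon of the core: 3-fluorophenyl in place of 4-(dimethylamino)phenyl on an aromatic carbon.

For the measured compounds named here, only one measured step bears directly on this change. It is a 1.6-fold higher number from compound 1 to compound 2 (0.21 log units; within the scatter), where 6-fluoropyridin-3-yl and 4-(dimethylamino)phenyl are exchanged at the same place, and it stays within the scatter. Going by the values given here, the fluorinated ring of compound 1 is the nearest measured neighbour of the entering group, though no measured compound carries 3-fluorophenyl itself. Compound 3, at 1080 nM, shows that not every group at this place stays close to compound 2, so the range must be kept wide.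

No change beyond the scatter is therefore expected, and the expected step is a 1.2-fold lower number from compound 2 to compound 4 (0.07 log units; within the scatter). For compound 4 the estimated value is 200 nM, with an expected range from 80 nM to 500 nM.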

Compound 4, half-maximal inhibitory concentration: 84.7 nM
Estimate against measurement, compound 4: 2.4-fold (0.37 log units) above; low and high end bracket the measured number.
By their numbers in this assay, from the lowest: compounds 4, 1 and 2 (each within the scatter of the next, the first and the last beyond it); then compound 3.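

In this assay, replacing 4-(dimethylamino)phenyl with 3-fluorophenyl on this aromatic carbon gives a 2.8-fold lower number from compound 2 to compound 4 (0.45 log units; beyond the scatter), so this position can move the number beyond the scatter towards stronger inhibition as well as towards weaker inhibition, which compound 3 had already shown. Replacing 6-fluoropyridin-3-yl with 3-fluorophenyl gives a 1.7-fold lower number from compound 1 to compound 4 (0.23 log units; within the scatter), so these two fluorinated rings cannot be told apart in this assay, although the entering ring has only carbon in it and no hydrogen-bond acceptor is counted for it. Because compound 2 stays within the scatter of compound 1, the fluorinated groups do not form a cleanly separate set, and only the exchange leading to compound 4 stands clear of the scatter.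

No measurement offered here accounts for the difference between these groups.

The compounds shown do not reveal whether the fluorine contributes at all, which an unsubstituted phenyl ring would test directly. They also leave open how the same ring would behave with fluorine replaced by chlorine or by a methoxy group, or with a saturated amine such as morpholine in place of the aromatic group.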